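A few compounds are considered here, and "the series" means these few. Any claim that something is new, unique, unknown or untested is made for them only; others in the source may bear on it.

Measured so far:
- compound 1 `CCOC(=O)c1c(C)[n+]([O-])c2cc(-n3ccnc3)c(F)cc2[n+]1[O-]`: 77700 nM
- compound 2 `CCOC(=O)c1c(C)[n+]([O-])c2cc(-n3cncn3)c(F)cc2[n+]1[O-]`: 77700 nM
- compound 3 `Cc1c(C(=O)OCc2ccccc2)[n+]([O-])c2cc(F)c(-n3ccnc3)cc2[n+]1[O-]`: 77700 nM

In an ADME assay on J774.A1 cells (Mus musculus) for cytotoxicity, read by MTT assay, with a stated time of 72 h (a higher number here means a weaker inhibitor, a lower number a stronger inhibitor), compound 3 gives 77700 nM, level with both other measured compounds at the digits available, so no order can be drawn among the three.

The next compound is compound 4 `Cc1c(C(=O)OCc2ccccc2)[n+]([O-])c2cc(F)c(-n3cncn3)cc2[n+]1[O-]`, which keeps the ester of compound 3 and changes one group: 1H-1,2,4-triazol-1-yl in place of 1H-imidazol-1-yl on an aromatic carbon. The group sits on an aromatic carbon, ortho to the fluoro group.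

Going by the values given here, two measured steps bear on this. The closer one is no change at the digits printed from compound 1 to compound 2 (within the scatter), which is the same replacement of 1H-imidazol-1-yl by 1H-1,2,4-triazol-1-yl, made on the core of compound 1. The other is no change at the digits printed from compound 1 to compound 3 (within the scatter), which shows the ester change that separates compound 3 from compound 1. Neither step moved the value, but the series holds only these three compounds, so the support is thin.

Neither step gives a reason to expect a shift beyond the scatter, in either direction. In this assay the expected outcome is no change at the digits printed from compound 3 to compound 4 (within the scatter).

Compound 4 is estimated at 77700 nM, with an expected range from 50000 nM to 110000 nM.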

Compound 4, half-maximal inhibitory concentration: 77700 nM
Beside the measured number, compound 4's estimate shows no gap at the digits printed, within the range that was stated.
By their numbers in this assay, from the lowest: compounds 1, 2, 3 and 4 (each within the scatter of the next).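

In this assay, the replacement of 1H-imidazol-1-yl by 1H-1,2,4-triazol-1-yl on an aromatic carbon, ortho to a fluoro group, gives no change at the digits printed from compound 3 to compound 4 (within the scatter), so this swap has now been read on a second core: the same change on two cores in this assay, no change at the digits printed (within the scatter) from compound 1 to compound 2 and no change at the digits printed (within the scatter) from compound 3 to compound 4, 1.0-fold (0.00 log units) apart, within the scatter of two such steps

The ester change, earlier read only with 1H-imidazol-1-yl in place, now also gives no change at the digits printed from compound 2 to compound 4 (within the scatter) with 1H-1,2,4-triazol-1-yl in place: the same change on two cores in this assay, no change at the digits printed (within the scatter) from compound 1 to compound 3 and no change at the digits printed (within the scatter) from compound 2 to compound 4, 1.0-fold (0.00 log units) apart, within the scatter of two such steps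

The four compounds therefore complete a square in which each change has been read with either form of the other, and neither change alters the reading of the other at the digits printed.

All four compounds print the same value, so the set ties no group to any difference in this assay and cannot show what would move the reading. Still open, going by these compounds, is whether an amine such as piperazine in place of the five-membered aromatic ring, or a carboxylic acid in place of the ester, would give a value outside the scatter of these four.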